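Removing one chloro from a fused core: an estimate

A few compounds are considered here, and "the series" means these few. Any claim that something is new, unique, unknown or untested is made for them only; others in the source may bear on it.

On these data alone, in a functional assay on HCC 2998 cells (Homo sapiens) for cytotoxicity, read by sulforhodamine B assay, with a stated time of 48 h (on this read-out lower numbers stand for stronger inhibition of growth and higher numbers for weaker inhibition of growth), compound 2 `ClCc1ccccc1Cn1cnc2c(Cl)nc(Cl)nc21` gives "not determined" (no result reported), as no result was reported for it, so its own standing on this scale is unknown. Compound 3 `ClCc1ccccc1Cn1cnc2c(Cl)ncnc21` differs from it in one place: hydrogen in place of chloro on an aromatic carbon. Since compound 2 carries no value, the step from compound 2 to compound 3 cannot be given as a number; the expectation is that the step in this assay stays within the usual scatter rather than pointing clearly in either direction. A related compound, compound 1 `ClCc1ccc(Cn2cnc3c(Cl)ncnc32)cc1`, shares the core of compound 3 with the chloromethyl group set elsewhere on the benzyl ring. In this assay compound 1 gives 660 nM. Compound 3 is therefore expected to give about 800 nM, with a range from 250 nM to 3000 nM, resting mainly on the value of compound 1, 660 nM.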

Compound 3, concentration for 50% growth inhibition: 1660 nM
Compound 3: the middle estimate sits 2.1-fold (0.32 log units) below what was measured; measured number inside the range.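

Within the data shown here, compound 2 has no number on this scale, so no step from compound 2 to compound 3 can be read. The compounds shown leave open whether the chloro between two ring nitrogen atoms matters for growth inhibition. Nothing shown here bears on the result for compound 3.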